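Amino to methyl on the five-membered ring: series notes

A few compounds are considered here, and "the series" means these few. Any claim that something is new, unique, unknown or untested is made for them only; others in the source may bear on it.

Measured compounds:
- compound 1 `Cc1ccc2oc(CSc3nnc(C)s3)cc(=O)c2c1`: > 25000 nM
- compound 2 `Cc1ccc2oc(CSc3nnc(N)s3)cc(=O)c2c1`: > 25000 nM
- compound 3 `Nc1nnc(SCc2coc3ccccc3c2=O)s1`: 730 nM

In a functional assay on LM7 cells (Homo sapiens) for cytotoxicity, read by MTT assay, with a stated time of 72 h (on this read-out lower numbers stand for stronger inhibition and higher numbers for weaker inhibition), compound 1 gives > 25000 nM, which is a limit of the assay and not a number. Compound 2 also gives only a limit, > 25000 nM. Going by the values given here, compound 3 gives 730 nM, the only number in the set; the other two values sit at the limit of > 25000 nM in this assay, at which 2 of the 3 values shown sit. How the core of compound 2 differs from the core of compound 3 is not broken down here.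

From compound 2 to compound 1 the change is methyl in place of amino on an aromatic carbon; the step is a step that the two limits leave unreadable from compound 2 to compound 1, both ends being limits.

Compound 4 `Cc1nnc(SCc2coc3ccccc3c2=O)s1` is not yet measured. From compound 3 to compound 4 the change is methyl in place of amino on an aromatic carbon; the place descriptions of the two changes agree word for word, so this is the same change as in the measured pair, which gives no readable size. For compound 4 the expected step is a 2.1-fold higher number from compound 3 to compound 4 (0.31 log units; beyond the scatter), resting on compound 3 at 730 nM as the only numerical anchor. Compound 4 is estimated at 1500 nM, between 400 nM and 8000 nM.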

Compound 4, half-maximal inhibitory concentration: 430 nM
The estimate for compound 4 lay 3.5-fold (0.54 log units) above the measured number; the range from low to high includes it.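

In this assay, replacing 5-amino-1,3,4-thiadiazol-2-yl with 5-methyl-1,3,4-thiadiazol-2-yl gives a 1.7-fold lower number from compound 3 to compound 4 (0.23 log units; within the scatter), so on this core the amino group and the methyl group cannot be told apart in this read-out. On the other core, the same change cannot be read, as compound 2 and compound 1 each give only a limit of the assay and not a number: the limit of > 25000 nM in this assay, at which 2 of the 4 values shown sit. The change therefore has one readable size on one core, which shows nothing about whether that size carries over to the core of compound 1, and a single pair sets up no rule for the series.

From the compounds shown here alone, it remains open what a carboxylic acid, a dimethylamino group or a longer chain such as propyl would give in this assay in place of the amino group on the core of compound 3. Also open, going by these compounds, is whether any group on the core of compound 1 would give a number instead of a limit.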